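The source may hold more compounds than are shown below. What is called first, only, known or untested is meant among the compounds shown, and "the series" means these compounds.

Measured compounds:
- compound 1, `CCSc1ccc(-c2nccc3[nH]c(C(C)(C)O)cc23)cc1`: 17200 nM
- compound 2, `CC(C)(O)c1cc2c(Cl)nccc2[nH]1`: 15500 nM

Both numbers come from an ADME assay on U2OS cells (Homo sapiens) for cytotoxicity; on this read-out lower numbers stand for higher toxicity in this test and higher numbers for lower toxicity in this test. Compound 2, with `CC(C)(O)c1cc2c(Cl)nccc2[nH]1`, gives 15500 nM in this assay; compound 1, with `CCSc1ccc(-c2nccc3[nH]c(C(C)(C)O)cc23)cc1`, gives 17200 nM. The two values lie within the scatter of each other, so no order between them can be read, and nothing on the series says how a change at the place in question moves the number. Within the data shown here, no step between measured compounds is available.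

Compound 3, `CC(C)(O)c1cc2c(-c3ccsc3)nccc2[nH]1`, is not yet measured in this assay. Relative to compound 2 the change is thiophen-3-yl in place of chloro on an aromatic carbon.

Among the measured compounds shown here, with no measured step of this kind to lean on, the expectation is that the step of a 1.3-fold lower number from compound 2 to compound 3 (0.11 log units; within the scatter) stays within the scatter, with a slight lean toward a lower number. Compound 3 is therefore expected to give about 12000 nM in this assay, with a plausible range from 5000 nM to 30000 nM, the wide band reflecting the absence of any comparable step in the data.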

Compound 3, half-maximal cytotoxic concentration: 199000 nM
Compound 3: the middle estimate sits 17-fold (1.22 log units) below what was measured; the whole stated range lies below it.
By their numbers in this assay, from the lowest: compounds 2 and 1 (each within the scatter of the next); then compound 3.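

In this assay, among these compounds, thiophen-3-yl in place of chloro on the aromatic carbon next to the ring nitrogen gives a 13-fold higher number from compound 2 to compound 3 (1.11 log units; beyond the scatter), the first evidence that a change at this position can move the number well beyond the scatter, here toward lower toxicity in this test. An aromatic ring at this carbon does not by itself give such a number: compound 1, which also carries one there, gives 17200 nM, within the scatter of compound 2, so the outcome depends on which ring is present or how it is substituted. No measurement shown here explains the step, so its origin remains unassigned.

The compounds shown leave open whether the high number belongs to thiophen-3-yl specifically or would also appear with an unsubstituted phenyl or a thiophen-2-yl ring at this carbon. They also leave open how non-aromatic replacements for chloro, such as a primary amine, a carboxylic acid or a longer alkyl chain, would move the number, and whether an ethyl group on the thiophen-3-yl ring would bring it back toward the values of compound 1 and compound 2.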